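Cytotoxicity notes on a methoxy-extended pair

The source may report more compounds than this note shows. Statements on the series, on what has been measured and on what is new or still open speak of the compounds shown alone.

Compound 1 `COc1ccc(CCCc2ccc(OC)cc2OC)c(O)c1` stands on one core; in an ADME assay on RAW264.7 cells (Mus musculus) for cytotoxicity, read by MTT assay, with a stated time of 24 h, tested at 5 ug/mL (on this read-out lower numbers stand for a stronger effect and higher numbers for a weaker effect at the one concentration tested), compound 1 gives 91.5%. Compound 2 `COc1ccc(C(=O)/C=C/c2ccc(OC)c(OC)c2OC)c(O)c1` and compound 3 `COc1ccc(C(=O)/C=C/c2cccc(OC)c2OC)c(O)c1` stand on another core; in this assay compound 2 gives 72.5% and compound 3 gives 69.7%. The difference between the core of compound 1 and the core of compound 3 is not broken down here. On the second core the change methoxy in place of hydrogen on an aromatic carbon gave a number 2.8 percentage points higher from compound 3 to compound 2 (within the scatter). Compound 4 `COc1ccc(CCCc2ccc(OC)c(OC)c2OC)c(O)c1` is not yet measured; it arises from compound 1 by methoxy in place of hydrogen on an aromatic carbon, the same kind of change, though here the entering group sits ortho to two methoxy groups and meta to a large group rather than ortho to a methoxy group, meta to a methoxy group and para to a large group. The step in this assay is expected to be a number 1.5 percentage points lower from compound 1 to compound 4 (within the scatter) because a number 2.8 percentage points higher from compound 3 to compound 2 (within the scatter) was small. Compound 4 is therefore estimated at 90%, between 78% and 100%.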

Compound 4, a percentage reported as activity, at one concentration (the size of the read-out at that concentration, not a potency): 84.5%
Compound 4: middle estimate off by 5.5 percentage points, on the high side; low and high end bracket the measured number.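

In this assay, methoxy in place of hydrogen on an aromatic carbon gave a number 7 percentage points lower from compound 1 to compound 4 (within the scatter). Set beside the earlier step on the other core, the two results do not separate: the same change on two cores in this assay, a number 2.8 percentage points higher (within the scatter) from compound 3 to compound 2 and a number 7 percentage points lower (within the scatter) from compound 1 to compound 4, 9.8 percentage points apart, within the scatter of two such steps. On these two pairs the change thus carries from one core to the other with no step beyond the scatter, but this does not show that it is without effect elsewhere, and as the entering group sits in a different place on each core, the roles of core and place cannot be told apart.

Still open, as far as these compounds go, is whether an amine, a carboxylic acid or a longer chain such as butoxy at this place would give a larger step. Also open is how any of these compounds would read at other concentrations.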